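The source may hold more compounds than are shown below. What is called first, only, known or untested is meant among the compounds shown, and "the series" means these compounds.

Measured compounds in a functional assay on MCF7 cells (Homo sapiens) for antiproliferative activity, read by MTT assay, with a stated time of 48 h; a higher number here means a weaker inhibitor, a lower number a stronger inhibitor:
compound 1 `N#CC1=C(N)Oc2c(c3nc4ccccc4nc3c3ccccc23)C12C(=O)N(Cc1cnnn1-c1ccc(Cl)cc1)c1ccccc12`: > 50000 nM, a limit of the assay and not a number
compound 2 `N#CC1=C(N)Oc2c(c3nc4ccccc4nc3c3ccccc23)C12C(=O)N(Cc1cnnn1-c1ccccc1Cl)c1ccccc12`: > 50000 nM, again a limit
compound 3 `Cc1ccccc1-n1nncc1CN1C(=O)C2(C(C#N)=C(N)Oc3c(N)cc4nc5ccccc5nc4c32)c2ccccc21`: > 50000 nM, again a limit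

Compound 3 stands where every measured member of the series stands: at the limit of this assay, with no number below it. Within the data shown here, the same holds for compound 1 and for compound 2, so the whole series so far is summed up by the limit of > 50000 nM in this assay, at which 3 of the 3 values shown sit.

Among the measured compounds shown here, the only step between measured compounds is a step that the two limits leave unreadable from compound 1 to compound 2, and it cannot be read in size because both of its ends are limits. For the measured compounds named here, no measured step carries a methoxy group, and none touches compound 3 at all.

Compound 4 `COc1ccc(-n2nncc2CN2C(=O)C3(C(C#N)=C(N)Oc4c(N)cc5nc6ccccc6nc5c43)c3ccccc32)cc1` differs from compound 3 as follows: 4-methoxyphenyl in place of 2-methylphenyl on an aromatic nitrogen.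

With no readable step to lean on, and with every compound of the series at the limit, the expectation for compound 4 is that it stays at the same limit; the estimated step that the limit leaves unreadable from compound 3 to compound 4 is therefore one of no change beyond the scatter. Compound 4 is estimated at 60000 nM in this assay, within a range of 20000 nM to 200000 nM, most likely reported as a limit only.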

Compound 4, half-maximal inhibitory concentration: > 50000 nM
Compound 4 was reported as a limit; the forecaster's own chance of this, stated with the estimate: 85%; the middle value is on the limit's open side.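

Among these compounds, compound 3 and compound 4 both sit at a limit of the assay and not at a number, so no step between them can be read. The series now reads: the limit of > 50000 nM in this assay, at which 4 of the 4 values shown sit.

The compounds shown leave open whether any member gives a measurable value in this assay, and how the groups on the aromatic nitrogen rank against one another.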